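Changing the aryl group on the amide carbonyl

The compounds below may be only part of what the source reports. "The series", "measured", "known", "first", "only" and "open" are said of these compounds alone.

Compound 2 `Cc1ccccc1C(=O)Nc1cccc(-c2oc3cc(-c4ccc(F)cc4)ccc3c(=O)c2O)c1` and compound 1 `COc1ccccc1C(=O)Nc1cccc(-c2oc3cc(-c4ccc(F)cc4)ccc3c(=O)c2O)c1` share one core and differ only in the group on the aromatic ring of the amide. Within the data shown here, in a functional assay on HCC1937 cells (Homo sapiens) for antiproliferative activity, read by CCK-8 assay, with a stated time of 72 h (on this read-out lower numbers stand for stronger inhibition and higher numbers for weaker inhibition), compound 1 gives 9050 nM, and compound 2 gives 9900 nM; the step of a 1.1-fold higher number from compound 1 to compound 2 (0.04 log units; within the scatter) leaves the pair essentially level, so compound 2 stands within the scatter of its only neighbour. Compound 3 `O=C(Nc1cccc(-c2oc3cc(-c4ccc(F)cc4)ccc3c(=O)c2O)c1)c1ccc(C(F)(F)F)cc1` carries a different ring on that amide: 4-(trifluoromethyl)phenyl in place of 2-methylphenyl on a carbonyl carbon. Among the measured compounds shown here, no measured step makes this kind of exchange; the one step known, from compound 1 to compound 2, is a small change on the same ring and stayed within the scatter. On that basis no movement beyond the scatter is expected, and the estimated step of a 1.1-fold lower number from compound 2 to compound 3 (0.04 log units; within the scatter) is taken as roughly flat. Compound 3 is therefore estimated at 9000 nM, with a range of 3000 nM to 27000 nM.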

Compound 3, half-maximal inhibitory concentration: 7350 nM
Estimate against measurement, compound 3: 1.2-fold (0.09 log units) above; measured number inside the range.
By their numbers in this assay, from the lowest: compounds 3, 1 and 2 (each within the scatter of the next).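

Replacing the whole ring on the amide carbonyl, rather than changing one small group on it, still leaves the compounds level in this assay, with a 1.3-fold lower number from compound 2 to compound 3 (0.13 log units; within the scatter) and a 1.2-fold lower number from compound 1 to compound 3 (0.09 log units; within the scatter) both within the scatter. This position therefore takes 4-(trifluoromethyl)phenyl, with 10 heavy atoms against 7 in 2-methylphenyl, without a read-out that can be told apart from those of the two earlier compounds. No evidence is available to explain this flat result.

Going by these compounds, whether any group on this carbonyl can shift the number beyond the scatter remains open, for example a ring bearing an amine or a carboxylic acid, or a saturated alkyl chain in place of the aromatic ring. On these data alone, whether the shared core, rather than this amide ring, governs the activity also remains open.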